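This account rests on a few compounds, and the source may have more. Where it says the series, first, only, none or still open, it means among the compounds named here.

Compound 1, `CCCCCn1ccc2cc(/C(C)=C/C(=O)Nc3ccccc3OCCCC(=O)O)ccc21`: 23 nM
Compound 2, `CCCCC(CCCC)n1ccc2cc(/C(C)=C/C(=O)Nc3ccccc3OCCCC(=O)O)ccc21`: 21 nM

In an assay on Prostate gland for inhibition of steroid 5-alpha-reductase (Rattus norvegicus) (on this read-out lower numbers stand for stronger inhibition and higher numbers for weaker inhibition), compound 2 gives 21 nM, and compound 1 gives 23 nM. The step of a 1.1-fold lower number from compound 1 to compound 2 (0.04 log units; within the scatter) lies within the scatter, so the two compounds cannot be told apart on this read-out; neither stands out.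

Compound 3, `C/C(=C\C(=O)Nc1ccccc1OCCCC(=O)O)c1ccc2c(ccn2C(C(C)C)C(C)C)c1`, differs from compound 2 by 1-isopropyl-2-methylpropyl in place of 1-butylpentyl on an aromatic nitrogen. Within the data shown here, the only measured step touching this position is the one from compound 1 to compound 2, in which butyl replaced hydrogen on the chain carbon bound to the aromatic nitrogen, and it stayed within the scatter. Nothing in the data shows that a change in the size or branching of this chain moves the number beyond the scatter. The expected step is therefore a 1.2-fold higher number from compound 2 to compound 3 (0.08 log units; within the scatter), which is expected to stay within the scatter. Compound 3 is estimated at 25 nM, with a range from 10 nM to 60 nM.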

Compound 3, half-maximal inhibitory concentration: 14 nM
For compound 3 the middle estimate is 1.8-fold (0.25 log units) above the measured one; low and high end bracket the measured number.
By their numbers in this assay, from the lowest: compounds 3, 2 and 1 (each within the scatter of the next).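

In this assay, a 1.5-fold lower number from compound 2 to compound 3 (0.18 log units; within the scatter) stays within the scatter, even though 1-isopropyl-2-methylpropyl brings 7 heavy atoms to the aromatic nitrogen where 1-butylpentyl carried 9. The a 1.6-fold lower number from compound 1 to compound 3 (0.22 log units; within the scatter) also stays within the scatter, so pentyl, 1-butylpentyl and 1-isopropyl-2-methylpropyl cannot be told apart on this read-out. Among these compounds, the single earlier step rested on one change to the chain, whereas three all-carbon, ring-free groups on this nitrogen now give numbers that lie within the scatter of one another.

The compounds shown leave open whether a group carrying an amine or a carboxylic acid, or a hydrogen alone on the aromatic nitrogen, would move the number beyond the scatter. No available evidence bears on this result.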